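A few compounds are considered here, and "the series" means these few. Any claim that something is new, unique, unknown or untested is made for them only; others in the source may bear on it.

Of the compounds shown here, two have been tested so far in a functional assay on HL-60 cells (Homo sapiens) for cytotoxicity; on this read-out lower numbers stand for stronger inhibition and higher numbers for weaker inhibition. Compound 1 `C/C(=C\c1ccccc1C(=O)O)c1ccc2c(c1)C(C)(C)CCC2(C)C` carries a carboxylic acid on one ring and a bulky saturated ring system on the other, joined through a double bond. For compound 1 this assay reports only a limit, > 100000 nM, which means no number could be fixed. Compound 2 `CC1(C)CCC(C)(C)c2cc(/C=C/c3ccc(N)cc3)ccc21` replaces the acid-bearing ring by an amino-bearing ring and in this assay compound 2 gives 18000 nM.

Compound 3 `C/C(=C/c1ccccc1C(=O)O)c1ccc2c(c1)C(C)(C)CCC2(C)C` is the partner of compound 1 with the double bond drawn the other way: the two compounds have the same atoms and bonds and differ only in configuration as drawn: 1 of 1 stereo elements differ; a double bond is drawn E in compound 1 and Z in compound 3. For the measured compounds named here, no measured pair in this set differs by such a flip, so no measured step tells how large an effect to expect. Since compound 1 sits at the limit, as the evidence the limit of > 100000 nM in this assay, at which 1 of the 2 values shown sits, shows, a weak result for compound 3 seems the safer expectation, and the change from compound 1 to compound 3 is expected to be about an at least 1.1-fold lower number from compound 1 to compound 3 (0.04 log units; that floor lies within the scatter), within the scatter. Compound 3 is therefore expected to reach roughly 90000 nM in this assay, with a plausible range from 15000 nM to 300000 nM.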

Compound 3, half-maximal inhibitory concentration: 52000 nM
Compound 3: middle estimate off by 1.7-fold (0.24 log units), on the high side, within the range that was stated.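

For the compounds shown here, compound 3 is the first compound carrying the carboxylic acid to give a real number in this assay, and any gap between it and compound 1 can only lie in the configuration of the double bond: the fact that compounds 1 and 3 differ only in the configuration as drawn. Compound 1 stays at > 100000 nM, which is a limit of the assay and not a number. The effect of the flip can therefore be read only as a floor, an at least 1.9-fold lower number from compound 1 to compound 3 (0.28 log units; that floor lies within the scatter), so the true gap may be larger, but the floor alone does not show that configuration matters here.

On these data alone, whether a methyl ester or an amide in place of the carboxylic acid of compound 3 would move the number remains open, as does the role of the methyl group on its double bond. Compound 2 differs from compound 3 in more than one place, so it gives no clean comparison and cannot show whether the amine or the carboxylic acid is the better group to carry.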